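The source may hold more compounds than are shown below. What is called first, only, known or untested is meant among the compounds shown, and "the series" means these compounds.

Measured so far in a functional assay on MDA-MB-231 cells (Homo sapiens) for inhibition, read by MTT assay, with a stated time of 72 h; a higher number here means a weaker inhibitor, a lower number a stronger inhibitor:
compound 1, `O=C(CSc1nc(Nc2ccccc2)c2ccccc2n1)Nc1cccc([N+](=O)[O-])c1`, gives 33000 nM
compound 2, `CCc1cccc(NC(=O)CSc2nc(Nc3ccccc3)c3ccccc3n2)c1`, gives 12400 nM

For the measured compounds named here, compound 2 holds the lower of these two numbers, so it is the stronger inhibitor of the pair, and the only step measured so far leads to it: a 2.7-fold lower number from compound 1 to compound 2 (0.43 log units; beyond the scatter), brought about by ethyl in place of nitro on an aromatic carbon. That is the whole of the evidence available.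

Compound 3, `O=C(CSc1nc(Nc2ccccc2)c2ccccc2n1)Nc1ccc(F)c(Cl)c1`, is the next step and has not yet been measured. It differs from compound 2 by 3-chloro-4-fluorophenyl in place of 3-ethylphenyl on an amide-type nitrogen. Going by the values given here, the one measured step bears on this only loosely: it showed that swapping the group on that same amide-type nitrogen can move the number modestly, but it said nothing about chlorine or fluorine. Two halogens replacing an ethyl on an otherwise unchanged scaffold give no clear reason to expect a large shift in either direction. Compound 3 is therefore expected to land at about 10000 nM, within an estimated range of 4000 nM to 25000 nM. The step this estimate implies, a 1.2-fold lower number from compound 2 to compound 3 (0.09 log units; within the scatter), is expected to stay near the scatter.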

Compound 3, half-maximal inhibitory concentration: 21600 nM
The estimate for compound 3 lay 2.2-fold (0.33 log units) below the measured number, and the stated range covers the measured number.
By their numbers in this assay, from the lowest: compounds 2, 3 and 1 (each within the scatter of the next, the first and the last beyond it).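

Set against 3-ethylphenyl (a 1.7-fold higher number from compound 2 to compound 3 (0.24 log units; within the scatter)) and 3-nitrophenyl (a 1.5-fold lower number from compound 1 to compound 3 (0.18 log units; within the scatter)), the 3-chloro-4-fluorophenyl group on the amide-type nitrogen stays within the scatter on both sides in this assay. Compound 3 therefore cannot be ranked against compound 1 or compound 2, even though those two lie beyond the scatter of each other, so the data give no sign that this halogen-bearing ring is better or worse than either earlier group. No measurement is available that could explain why these three rings on the same nitrogen give the numbers they do.

All three groups at this position are six-membered aromatic carbon rings, so the compounds shown leave open what an amine, a carboxylic acid or a longer chain would do on that nitrogen. They also leave open whether the chlorine or the fluorine alone would give a similar number, and whether changes elsewhere on the shared core would move the number further than changes at this position have.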